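The source may hold more compounds than are shown below. What is called first, only, known or untested is meant among the compounds shown, and "the series" means these compounds.

Among the compounds with values here, in a functional assay on cells (Homo sapiens) for inhibition (a lower number here means a stronger inhibitor, a higher number a weaker inhibitor), three related compounds have numbers so far. Compound 1 `O=C(/C=C\N(O)Cc1ccccc1)c1ccc2ccccc2c1` gives 5400 nM, compound 2 `O=C(/C=C\N(O)Cc1ccc2ccccc2c1)c1ccc(F)cc1` gives 7700 nM, and compound 3 `O=C(/C=C\N(O)Cc1ccccc1)c1ccc(Cl)c(Cl)c1` gives 3600 nM. Compound 2 therefore stands level with compound 1 within the usual scatter, while its number lies higher than that of compound 3, a gap just beyond the scatter.

Compound 4 `O=C(/C=C\N(O)Cc1ccc2ccccc2c1)C1CC1` keeps the rest of compound 2 but has cyclopropyl in place of 4-fluorophenyl on a carbonyl carbon. Within the data shown here, no measured pair shows this change directly, so any forecast is uncertain. Compound 2, at 7700 nM, has an aromatic group at this place, as do compounds 1 and 3, whereas the new group is non-aromatic and smaller. A moderate rise in the number, meaning a weaker inhibitor, is therefore expected, although a step within the scatter remains possible. The estimated step is a 1.8-fold higher number from compound 2 to compound 4 (0.26 log units; within the scatter). For compound 4 the estimated value is 14000 nM, with an expected range of 5000 nM to 40000 nM.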

Compound 4, half-maximal inhibitory concentration: 9900 nM
Beside the measured number, compound 4's estimate is 1.4-fold (0.15 log units) above it, within the range that was stated.
By their numbers in this assay, from the lowest: compounds 3, 1, 2 and 4 (each within the scatter of the next, the first and the last beyond it).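

In this assay, cyclopropyl in place of 4-fluorophenyl on a carbonyl carbon gives a 1.3-fold higher number from compound 2 to compound 4 (0.11 log units; within the scatter), so compound 2 and compound 4 stand level. Compounds 1, 2 and 3 all carry an aromatic group at this place, so they could not show whether such a ring matters here; compound 4 shows that a non-aromatic ring of 3 heavy atoms can take the place of one of 7 with no change beyond the scatter. Nothing measured here bears on why these two numbers stand level.

On these data alone, it remains open whether an amine, a carboxylic acid or a longer chain such as butyl on this carbonyl carbon would also stand level with compound 2. As far as these compounds go, it is also open whether cyclopropyl would give the same result when swapped into compound 1 or compound 3.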